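Moving the chlorine on a chalcone with a thioester tail

The compounds below may be only part of what the source reports. "The series", "measured", "known", "first", "only" and "open" are said of these compounds alone.

Compound 1 `O=C(CCl)Nc1ccc(C(=O)/C=C/c2ccccc2Cl)cc1` and compound 2 `O=C(CCl)Nc1ccc(C(=O)/C=C/c2cccc(Cl)c2)cc1` share a core and differ only in 3-chlorophenyl in place of 2-chlorophenyl on a double-bonded chain carbon bound to a double-bonded chain carbon. In a functional assay on EC9706 cells (Homo sapiens) for cytotoxicity, read by MTT assay, with a stated time of 72 h (on this read-out higher numbers stand for weaker inhibition and lower numbers for stronger inhibition), compound 1 gives 6980 nM, and compound 2 gives 5560 nM, so a 1.3-fold lower number from compound 1 to compound 2 (0.10 log units; within the scatter). Compound 3 `O=C(CSC(=S)N[C@H]1CCOC1=O)Nc1ccc(C(=O)/C=C/c2ccccc2Cl)cc1` carries a larger tail, (a group of 10 heavy atoms (5 carbon, 1 nitrogen, 2 oxygen, 2 sulfur; one five-membered non-aromatic ring with 1 hetero atom) in place of one chlorine atom, on a saturated chain carbon bound to a carbonyl carbon), and in this assay compound 3 gives 34100 nM, with a 4.9-fold higher number from compound 1 to compound 3 (0.69 log units; beyond the scatter). Compound 4 `O=C(CSC(=S)N[C@H]1CCOC1=O)Nc1ccc(C(=O)/C=C/c2cccc(Cl)c2)cc1` is not yet measured; it differs from compound 3 by 3-chlorophenyl in place of 2-chlorophenyl on a double-bonded chain carbon bound to a double-bonded chain carbon, the same change already seen between the first two compounds, at the same place. Since that earlier move stayed within the scatter, compound 4 is expected to sit close to compound 3, with an estimated step of a 1.3-fold lower number from compound 3 to compound 4 (0.10 log units; within the scatter). The estimate for compound 4 is therefore 27000 nM, somewhere between 13000 nM and 56000 nM.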

Compound 4, half-maximal inhibitory concentration: 32500 nM
Estimate against measurement, compound 4: 1.2-fold (0.08 log units) below; low and high end bracket the measured number.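

In this assay, putting 3-chlorophenyl in place of 2-chlorophenyl on the core with the larger tail gives a 1.0-fold lower number from compound 3 to compound 4 (0.02 log units; within the scatter), and this small step carries over from the core with the chloroacetyl tail: the same change on two cores in this assay, a 1.3-fold lower number (0.10 log units; within the scatter) from compound 1 to compound 2 and a 1.0-fold lower number (0.02 log units; within the scatter) from compound 3 to compound 4, 1.2-fold (0.08 log units) apart, within the scatter of two such steps. The larger tail in place of the chlorine atom also behaves alike on the 3-chlorophenyl compounds, with a 5.8-fold higher number from compound 2 to compound 4 (0.77 log units; beyond the scatter), a step that agrees with the earlier one: the same change on two cores in this assay, a 4.9-fold higher number (0.69 log units; beyond the scatter) from compound 1 to compound 3 and a 5.8-fold higher number (0.77 log units; beyond the scatter) from compound 2 to compound 4, 1.2-fold (0.08 log units) apart, within the scatter of two such steps. So across these four compounds the two changes appear to act independently, but this does not rank the two chlorine placements or show that the pattern extends to other groups.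

From the compounds shown here alone, it remains open whether an amine in place of the ring chlorine would shift the number. The same applies to a longer chain in place of the larger tail.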